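Chlorobenzyl position shift on the thioether in two cores

The source may report more compounds than this note shows. Statements on the series, on what has been measured and on what is new or still open speak of the compounds shown alone.

Of the compounds shown here, three have been measured in a functional assay on the whole organism (artery, strain albino) with Rattus norvegicus as the target, with a stated time of 300 min, at a dose of 10 mg/kg by the oral route; a lower number here means less inhibition, a higher number more inhibition at the dose given (going by the name of the read-out). Compound 1 `COc1ccc(C2N=C(SCc3cccc(Cl)c3)NC(C)=C2C(=O)Nc2ccc(F)cc2)cc1OC` gives 16.4%. Compound 2 `COc1ccc(C2N=C(SCc3ccc(Cl)cc3)NC(C)=C2C(=O)Nc2ccc(F)cc2)cc1OC` differs from compound 1 only by 4-chlorophenyl in place of 3-chlorophenyl on a saturated chain carbon bound to a sulfur. In this assay compound 2 gives 31.3%. For the measured compounds named here, the step of a number 14.9 percentage points higher from compound 1 to compound 2 (beyond the scatter) is the single measured pair that isolates this change. Compound 3 `CC1=C(C(=O)Nc2ccc([N+](=O)[O-])cc2)C(c2ccc(Br)cc2)N=C(SCc2cccc(Cl)c2)N1` gives 9.2%. The difference between the core of compound 3 and the core of compound 1 is not broken down here. The number for compound 3 lies within the scatter of the number for compound 1, so no order between these two can be claimed, while it stands beyond the scatter below the number for compound 2.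

Compound 4 `CC1=C(C(=O)Nc2ccc([N+](=O)[O-])cc2)C(c2ccc(Br)cc2)N=C(SCc2ccc(Cl)cc2)N1` has not been measured in this assay. It differs from compound 3 by 4-chlorophenyl in place of 3-chlorophenyl on a saturated chain carbon bound to a sulfur, the same change made from compound 1 to compound 2, at the same place. Going by the values given here, only one measured instance of the change exists, and the core of compound 3 differs from the core of compound 1 in ways not counted, so the carry-over is uncertain. A step of about a number 12.8 percentage points higher from compound 3 to compound 4 (beyond the scatter) is expected because the matching change gave a number 14.9 percentage points higher from compound 1 to compound 2 (beyond the scatter) in this assay. Compound 4 is therefore estimated at 22% in this assay, with a range from 5% to 40% that covers the chance that the change does not carry over at all.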

Compound 4, a percentage reported as inhibition, in the whole organism at one dose (the size of the read-out at that dose, not a potency): 37.9%
For compound 4 the middle estimate is 15.9 percentage points below the measured one, and the stated range covers the measured number.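

In this assay the change from 3-chlorobenzyl to 4-chlorobenzyl on the sulfur gives a number 28.7 percentage points higher from compound 3 to compound 4 (beyond the scatter), so on both cores shown the change runs in the same direction and each step stands beyond the scatter. The two steps cannot be told apart in size, so the change can be treated as carrying over between these two cores with a comparable step: the same change on two cores in this assay, a number 14.9 percentage points higher (beyond the scatter) from compound 1 to compound 2 and a number 28.7 percentage points higher (beyond the scatter) from compound 3 to compound 4, 13.8 percentage points apart, within the scatter of two such steps. This rests on two pairs only: it sets no rule for other cores in the series, does not show that the step is larger on one core than on the other, and says nothing on why the change acts as it does.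

The cores of compound 1 and compound 3 differ in more than one place, so the compounds shown leave open which part of the core, if any, bears on the size of the step. Also open, from the compounds shown here alone, is how the thioether position responds beyond the two chlorobenzyl groups, for instance to a plain benzyl group, a bromobenzyl group, or a longer chain between the sulfur and the ring.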